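This account rests on a few compounds, and the source may have more. Where it says the series, first, only, none or still open, it means among the compounds named here.

Measured compounds:
compound 1 `COc1ccc(Cn2cc(CNC(=O)c3cn(-c4ccccc4)nc3-c3ccc(F)cc3)nn2)cc1` with 650 nM
compound 2 `COc1ccc(Cn2cc(CNC(=O)c3cn(-c4ccccc4)nc3-c3ccc(Cl)cc3)nn2)cc1` with 8000 nM
compound 3 `COc1ccc(-c2nn(-c3ccccc3)cc2C(=O)NCc2cn(Cc3ccc(Cl)cc3)nn2)cc1` with 2900 nM

In a functional assay on MCF7 cells (Homo sapiens) for antiproliferative activity, read by sulforhodamine B assay, with a stated time of 48 h (a lower number here means a stronger inhibitor of growth, a higher number a weaker inhibitor of growth), compound 3 sits second highest of the three numbers: compound 2 gives a higher number, compound 1 a lower one, both gaps beyond the scatter. Compound 4 `COc1ccc(Cn2cc(CNC(=O)c3cn(-c4ccccc4)nc3-c3ccc(OC)cc3)nn2)cc1` is made from compound 3 by the change (methoxy in place of chloro on an aromatic carbon), that is 4-chlorobenzyl to 4-methoxybenzyl. Within the data shown here, the only measured step, a 12-fold higher number from compound 1 to compound 2 (1.09 log units; beyond the scatter), swaps one halogen for another on the other aromatic ring, so it bears only loosely here and gives no direct guide for a halogen giving way to methoxy. Among the measured compounds shown here, with no closer precedent, the step of a 1.0-fold higher number from compound 3 to compound 4 (0.01 log units; within the scatter) is expected to stay within the scatter, though with wide uncertainty. Compound 4 is therefore estimated at 3000 nM, between 800 nM and 12000 nM.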

Compound 4, concentration for 50% growth inhibition: 22900 nM
Compound 4: middle estimate off by 7.6-fold (0.88 log units), on the low side; the whole stated range lies below it.
By their numbers in this assay, from the lowest: compound 1; then compound 3; then compound 2; then compound 4.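

In this assay methoxy in place of chloro gives a higher number on either aromatic ring, and both steps lie beyond the scatter: a 7.9-fold higher number from compound 3 to compound 4 (0.90 log units; beyond the scatter) at the 4-chlorobenzyl group, and a 2.9-fold higher number from compound 2 to compound 4 (0.46 log units; beyond the scatter) at the 4-chlorophenyl group. Methoxy in place of fluoro goes further still, with a 35-fold higher number from compound 1 to compound 4 (1.55 log units; beyond the scatter) on that same ring, so compound 4, with methoxy on both rings, is the weakest of the four. Going by these compounds, an amine or a hydroxyl group at this position remains open, as does whether either would track the halogens or methoxy. Nothing available explains why methoxy weakens growth inhibition here.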